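This account rests on a few compounds, and the source may have more. Where it says the series, first, only, none or still open, it means among the compounds named here.

Working notes on the series.

Among the compounds with values here, compound 1 `CC1(C[C@@H](O)C(=O)N2N=CC[C@H]2C(=O)NCc2cc(Cl)ccc2-n2cnnn2)CC1` is the stronger of the two measured members: in a functional assay on a cell-free system (plasma, Homo sapiens), with a stated time of 3 min (a higher number here means a weaker inhibitor, a lower number a stronger inhibitor), compound 1 gives 730 nM, while compound 2 `CC(C)(C)[C@@H](O)C(=O)N1NCC[C@H]1C(=O)NCc1cc(Cl)ccc1-n1cnnn1` gives 1700 nM, a gap beyond the usual scatter. The two differ in more than one place, so the numbers alone are kept here without a step between them.

Compound 3 `O=C(NCc1cc(Cl)ccc1-n1cnnn1)[C@@H]1CC=NN1C(=O)[C@H](O)Cc1ccccc1` is the next member to be measured and differs from compound 1 in a single place: phenyl in place of 1-methylcyclopropyl on a saturated chain carbon, two bonds along the chain from a carbonyl carbon and an oxygen on a saturated carbon. Within the data shown here, no pair of measured compounds shows this change, so the size of the step rests on expectation only. The substituent is an uncharged carbon group in both cases, and a modest loss of potency, or none beyond the scatter, is expected; the step of a 1.4-fold higher number from compound 1 to compound 3 (0.14 log units; within the scatter) is the working estimate. For compound 3 in this assay a value of 1000 nM is expected, within a range from 300 nM to 3500 nM.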

Compound 3, half-maximal inhibitory concentration: 1400 nM
Estimate against measurement, compound 3: 1.4-fold (0.15 log units) below; measured number inside the range.
By their numbers in this assay, from the lowest: compounds 1, 3 and 2 (each within the scatter of the next, the first and the last beyond it).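

In this assay, within the data shown here, the step of a 1.9-fold higher number from compound 1 to compound 3 (0.28 log units; within the scatter) is the first single-place change that can be read: phenyl in place of 1-methylcyclopropyl on a saturated chain carbon, two bonds along the chain from a carbonyl carbon and an oxygen on a saturated carbon. At this position, then, a six-membered aromatic ring of carbon and a three-membered non-aromatic ring of carbon cannot be told apart beyond the scatter, although the heavy-atom count of the group differs. Nothing measured for these compounds accounts for the result.

Still open, on these data alone, is whether an amine, a carboxylic acid or a pyridine ring at this position would stay within the scatter of compound 1. Also open, as far as these compounds go, is whether phenyl would give a comparable step on the core of compound 2.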